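This account rests on a few compounds, and the source may have more. Where it says the series, first, only, none or still open, it means among the compounds named here.

In a functional assay on ACHN cells (Homo sapiens) (on this read-out lower numbers stand for stronger inhibition of growth and higher numbers for weaker inhibition of growth), compound 1 `O=S(=O)(/C=C/c1ccc(F)cc1)Cc1ccc(Nc2ncnc3ccccc23)cc1` gives 10 nM. Compound 2 `N#Cc1ccc(/C=C/S(=O)(=O)Cc2ccc(Nc3ncnc4ccccc34)cc2)cc1` gives > 100000 nM, which is a limit of the assay and not a number. Compound 3 `CC(C)(C)c1cc(/C=C/S(=O)(=O)Cc2ccc(Nc3ncnc4ccccc34)cc2)cc(C(C)(C)C)c1O` gives > 100000 nM, which is also a limit. Compound 2 therefore has no exact value and stands at the limit of > 100000 nM in this assay, at which 2 of the 3 values shown sit.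

Compound 4 `O=S(=O)(/C=C/c1ccc(Cl)cc1Cl)Cc1ccc(Nc2ncnc3ccccc23)cc1` has 2,4-dichlorophenyl in place of the 4-cyanophenyl of compound 2, on a double-bonded chain carbon bound to a double-bonded chain carbon: 2,4-dichlorophenyl in place of 4-cyanophenyl on a double-bonded chain carbon bound to a double-bonded chain carbon. Going by the values given here, the one measured step that bears directly on this change is an at least 10000-fold higher number from compound 1 to compound 2 (4.00 log units; beyond the scatter), a large step that came with cyano in place of fluoro on an aromatic carbon. Compound 4 loses that cyano group and carries chlorine instead, so a move back toward compound 1 seems plausible, though chlorine is not fluoro and the new group differs in more than one place. Caution comes from compound 3, which has no cyano group and still sits at the limit of > 100000 nM.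

A sizeable move to a lower number is therefore expected, but with much uncertainty. The estimated change is an at least 100-fold lower number from compound 2 to compound 4 (2.00 log units; beyond the scatter). For compound 4 the expected value is 1000 nM, with an estimated range from 20 nM to 50000 nM.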

Compound 4, concentration for 50% growth inhibition: 100 nM
For compound 4 the middle estimate is 10-fold (1.00 log units) above the measured one; the range from low to high includes it.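

In this assay, putting 2,4-dichlorophenyl in place of 4-cyanophenyl on a double-bonded chain carbon bound to a double-bonded chain carbon gives an at least 1000-fold lower number from compound 2 to compound 4 (3.00 log units; beyond the scatter). The value of compound 2, > 100000 nM, is a limit of the assay and not a number, which means this step has a known minimum but no exact size: the limit of > 100000 nM in this assay, at which 2 of the 4 values shown sit. Until now the compounds shown gave either a low value or a limit, and compound 4 is the first to fall in between, with a 10-fold higher number from compound 1 to compound 4 (1.00 log units; beyond the scatter), so this position accepts a ring with two chlorines while 4-fluorophenyl still gives the lower number.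

Compound 4 differs from compound 1 in both the kind of halogen and the number of halogens on the ring, so the compounds shown cannot say which of the two accounts for the step. On these data alone, it also remains open whether a phenyl ring carrying a single chlorine would sit nearer compound 1 or compound 4, and how a ring carrying an amine or a carboxylic acid would behave in this assay.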